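The source may hold more compounds than are shown below. What is called first, only, known or untested is meant among the compounds shown, and "the series" means these compounds.

Working notes on the series. Compound 1 `CNCC(=O)Nc1cc(OC)ccc1C(=O)c1ccc(OC)c2c1C=CC(C)(C)O2` and compound 2 `CCNCC(=O)Nc1cc(OC)ccc1C(=O)c1ccc(OC)c2c1C=CC(C)(C)O2` share one core. In a functional assay on HeLa cells (Homo sapiens) for antiproliferative activity, read by MTT assay, with a stated time of 48 h (a lower number here means a stronger inhibitor, a higher number a weaker inhibitor), compound 1 gives 2170 nM and compound 2 gives 4270 nM. The change between them, (methyl in place of hydrogen on a saturated chain carbon bound to an amine nitrogen), made a step of a 2.0-fold higher number from compound 1 to compound 2 (0.29 log units; within the scatter). Compound 3 `C=C(c1ccc(OC)cc1NC(=O)CNC)c1ccc(OC)c2c1C=CC(C)(C)O2` is built on a second core; the difference between the two cores is not broken down here. In this assay compound 3 gives 500 nM, the lowest number of the three. Compound 4 `C=C(c1ccc(OC)cc1NC(=O)CNCC)c1ccc(OC)c2c1C=CC(C)(C)O2` differs from compound 3 by the same change, (methyl in place of hydrogen on a saturated chain carbon bound to an amine nitrogen). The expected step is a 2.0-fold higher number from compound 3 to compound 4 (0.30 log units; within the scatter), resting on the earlier step of a 2.0-fold higher number from compound 1 to compound 2 (0.29 log units; within the scatter) made by this change. Compound 4 is estimated at 1000 nM in this assay, with a likely range from 400 nM to 2500 nM.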

Compound 4, half-maximal inhibitory concentration: 2590 nM
Compound 4: the middle estimate sits 2.6-fold (0.41 log units) below what was measured; the measured number lies above the stated range.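

In this assay, replacing methylamino with ethylamino on the core of compound 3 gives a 5.2-fold higher number from compound 3 to compound 4 (0.71 log units; beyond the scatter). This step and the one on the core of compound 1 do not differ beyond the scatter, so the change carries across these two cores within what two such steps can resolve: the same change on two cores in this assay, a 2.0-fold higher number (0.29 log units; within the scatter) from compound 1 to compound 2 and a 5.2-fold higher number (0.71 log units; beyond the scatter) from compound 3 to compound 4, 2.6-fold (0.42 log units) apart, within the scatter of two such steps This rests on a single pair per core, so it does not show that the step is the same size on both cores, nor that it would hold on any other core.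

The compounds shown leave open how a primary amine or a longer chain such as propylamino, in place of the methylamino group, would read on either core.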